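Lengthening a Chain on the Shared Core

The source may hold more compounds than are shown below. What is called first, only, known or untested is meant among the compounds shown, and "the series" means these compounds.

Of the compounds shown here, three have been measured in an assay on isolated protein for inhibition of high affinity 3',5'-cyclic-AMP phosphodiesterase 7A (Homo sapiens), read by cAMP accumulation, with a stated time of 10 min; on this read-out higher numbers stand for weaker inhibition and lower numbers for stronger inhibition. Compound 1 `COc1nc2c(c(=O)n(C)c(=O)n2C)n1CCCC(=O)Nc1ccc(C(C)(C)C)cc1` gives 19800 nM. Compound 2 `CCOc1nc2c(c(=O)n(C)c(=O)n2C)n1CCCC(=O)Nc1ccc(C(C)(C)C)cc1` differs from compound 1 by methyl in place of hydrogen on a saturated chain carbon bound to an oxygen on an aromatic ring; compound 2 gives 54300 nM, and the step of a 2.7-fold higher number from compound 1 to compound 2 (0.44 log units; beyond the scatter) points toward weaker inhibition. Compound 3 `CCCOc1nc2c(c(=O)n(C)c(=O)n2C)n1CCCC(=O)Nc1ccc(C(C)CC)cc1` carries a longer chain on that oxygen and a different group on the far ring; the difference between the cores of compound 1 and compound 3 is not broken down here. Compound 3 gives 9060 nM, the lowest number of the three.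

Compound 4 `CCCCOc1nc2c(c(=O)n(C)c(=O)n2C)n1CCCC(=O)Nc1ccc(C(C)CC)cc1` is not yet measured. It differs from compound 3 by methyl in place of hydrogen on a saturated chain carbon, three bonds along the chain from an oxygen on an aromatic ring. Among the measured compounds shown here, this is the same kind of change as the one from compound 1 to compound 2, but not the same: there the methyl enters on a saturated chain carbon bound to an oxygen on an aromatic ring, here on a saturated chain carbon three bonds along the chain from that oxygen. Because a 2.7-fold higher number from compound 1 to compound 2 (0.44 log units; beyond the scatter) moved toward weaker inhibition, a step of similar direction but smaller size is expected: a 1.5-fold higher number from compound 3 to compound 4 (0.19 log units; within the scatter). Compound 4 is estimated at 14000 nM, between 5000 nM and 40000 nM.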

Compound 4, half-maximal inhibitory concentration: 20000 nM
For compound 4 the middle estimate is 1.4-fold (0.15 log units) below the measured one, and the stated range covers the measured number.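

In this assay, the new step is a 2.2-fold higher number from compound 3 to compound 4 (0.34 log units; beyond the scatter), so going from propyl to butyl on the oxygen again moves the number toward weaker inhibition. Set beside the earlier step from methyl to ethyl, the change carries over from one core to the other in both direction and size: the same change on two cores in this assay, a 2.7-fold higher number (0.44 log units; beyond the scatter) from compound 1 to compound 2 and a 2.2-fold higher number (0.34 log units; beyond the scatter) from compound 3 to compound 4, 1.2-fold (0.09 log units) apart, within the scatter of two such steps. Among the compounds shown here, this agreement rests on only two pairs, which differ in the group on the far ring and in where the added methyl enters, so it does not show that the change would behave the same way on other cores or at other places on the chain.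

The compounds shown leave open whether a longer chain than butyl, such as pentyl or hexyl, would continue in the same direction. They also leave open what a chain carrying an amine or a carboxylic acid would give in place of butyl.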